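The compounds below may be only part of what the source reports. "The series", "measured", "known", "first", "only" and "open" are said of these compounds alone.

Compound 1 `CC1CCCCN1C(=S)SCc1ccc(C(=O)Nc2ccccc2N)cc1` and compound 2 `COc1ccc(N2CCN(C(=S)SCc3ccc(C(=O)Nc4ccccc4N)cc3)CC2)cc1` share one core and differ only in the amine portion attached to it. In a functional assay on MGC-803 cells (Homo sapiens) for antiproliferative activity, read by CCK-8 assay, with a stated time of 72 h, tested at 2 uM (a higher number here means a stronger effect of the compound at the concentration tested, a lower number a weaker effect), compound 1 gives 64.4%, whereas compound 2 gives 25.3%, the lowest of the two numbers and a gap beyond the usual scatter. Compound 3 `Cc1ccc(N2CCN(C(=S)SCc3ccc(C(=O)Nc4ccccc4N)cc3)CC2)cc1` keeps the whole framework of compound 2 and alters a single group on a six-membered aromatic ring of carbon only: methyl in place of methoxy on an aromatic carbon. Among the compounds with values here, no measured pair in this set differs in just that way, so the step has to be judged from the structures alone. A swap of methoxy for methyl of this sort is expected to leave the read-out close to where compound 2 sits, with any shift in either direction not exceeding the scatter, an expected step of a number 4.7 percentage points higher from compound 2 to compound 3 (within the scatter). On that basis compound 3 is estimated to reach 30% in this assay, most likely between 12% and 50%.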

Compound 3, a percentage reported as inhibition, at one concentration (the size of the read-out at that concentration, not a potency): 33.4%
Beside the measured number, compound 3's estimate is 3.4 percentage points below it, within the range that was stated.
By their numbers in this assay, from the lowest: compounds 2 and 3 (each within the scatter of the next); then compound 1.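

Swapping 4-methoxyphenyl for 4-methylphenyl gives the first measured step at this place, para to a large group: in this assay it reads a number 8.1 percentage points higher from compound 2 to compound 3 (within the scatter). Losing the methoxy oxygen, and with it the one hydrogen-bond acceptor of that group, therefore leaves the read-out within the scatter, and with methyl at this place compound 3 gives 33.4%. The data shown offer no measurement that bears on why these two groups read alike.

Going by these compounds, whether a group of another kind at this place, such as an amine, a carboxylic acid or a chlorine atom, would move the read-out beyond the scatter remains open. Also open, on these data alone, is how a plain hydrogen at this place would compare, so the contribution of any group there cannot yet be told.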